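Halogen additions on the shared core of compound 1

A few compounds are considered here, and "the series" means these few. Any claim that something is new, unique, unknown or untested is made for them only; others in the source may bear on it.

Compound 1 `O=[N+]([O-])c1cc(C(F)(F)F)cc([N+](=O)[O-])c1Oc1ccccc1/C=N\OCc1ccccc1` is the unsubstituted reference of the set; in a functional assay on MCF7 cells (Homo sapiens) for antiproliferative activity, read by MTT assay, with a stated time of 48 h (a lower number here means a stronger inhibitor, a higher number a weaker inhibitor), compound 1 gives 1330 nM. Compound 2 `O=[N+]([O-])c1cc(C(F)(F)F)cc([N+](=O)[O-])c1Oc1ccccc1/C=N\OCc1ccccc1F` differs from it by fluoro in place of hydrogen on an aromatic carbon, and in this assay compound 2 gives 700 nM; the step is a 1.9-fold lower number from compound 1 to compound 2 (0.28 log units; within the scatter). Compound 3 `O=[N+]([O-])c1cc(C(F)(F)F)cc([N+](=O)[O-])c1Oc1ccc(Br)cc1/C=N\OCc1ccccc1` differs from compound 1 by bromo in place of hydrogen on an aromatic carbon, and in this assay compound 3 gives 1150 nM, a step of a 1.2-fold lower number from compound 1 to compound 3 (0.06 log units; within the scatter). All three numbers sit within the scatter of one another, so no order among them is claimed.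

Compound 4 `O=[N+]([O-])c1cc(C(F)(F)F)cc([N+](=O)[O-])c1Oc1ccc(Br)cc1/C=N\OCc1ccccc1F` is not yet measured. It differs from compound 3 by fluoro in place of hydrogen on an aromatic carbon, the same change that separates compound 1 from compound 2, placed here on the core of compound 3, whose difference from the core of compound 1 is the bromo described above. Among the compounds with values here, the step from compound 3 to compound 4 in this assay is expected to be about a 1.8-fold lower number from compound 3 to compound 4 (0.25 log units; within the scatter), resting on the single earlier instance a 1.9-fold lower number from compound 1 to compound 2 (0.28 log units; within the scatter). Accordingly compound 4 is estimated at 650 nM, with a plausible range from 300 nM to 1400 nM.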

Compound 4, half-maximal inhibitory concentration: 1120 nM
Estimate against measurement, compound 4: 1.7-fold (0.24 log units) below, within the range that was stated.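

In this assay, fluoro in place of hydrogen on the bromo-bearing core gives a 1.0-fold lower number from compound 3 to compound 4 (0.01 log units; within the scatter), and this step does not differ from its earlier instance: the same change on two cores in this assay, a 1.9-fold lower number (0.28 log units; within the scatter) from compound 1 to compound 2 and a 1.0-fold lower number (0.01 log units; within the scatter) from compound 3 to compound 4, 1.9-fold (0.27 log units) apart, within the scatter of two such steps. Bromo in place of hydrogen on the fluoro-bearing core gives a 1.6-fold higher number from compound 2 to compound 4 (0.20 log units; within the scatter), and this step likewise does not differ from its earlier instance: the same change on two cores in this assay, a 1.2-fold lower number (0.06 log units; within the scatter) from compound 1 to compound 3 and a 1.6-fold higher number (0.20 log units; within the scatter) from compound 2 to compound 4, 1.9-fold (0.27 log units) apart, within the scatter of two such steps. The two pairs of steps therefore give no sign that either change depends on the core, but they do not show that an effect carries over, since every step lies within the scatter and each change has only two instances.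

The compounds shown leave open whether 2-fluorobenzyl would behave in the same way beside other groups in place of the bromo, such as chloro, methoxy or an amine. They also leave open what a carboxylic acid, a nitrile or a longer chain would do on the benzyl ring or the linking chain.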